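The source may hold more compounds than are shown below. What is called first, only, known or untested is meant among the compounds shown, and "the series" means these compounds.

Series notes, the amide end of the shared core.

Compound 1 `COc1cccc(C(=O)Nc2ccc(Cl)cc2CN2C(=O)c3ccccc3C2=O)c1` gives 1500 nM in an assay on CHO cells for positive allosteric modulation of metabotropic glutamate receptor 5 (Homo sapiens), read by FLIPR; a higher number here means that more compound is needed for the effect, a lower number that less compound is needed. Compound 2 `O=C(Nc1ccc(Cl)cc1CN1C(=O)c2ccccc2C1=O)c1ccccc1` reaches only the limit of this assay, > 100000 nM (the limit of > 100000 nM in this assay, at which 1 of the 3 values shown sits). Compound 3 `O=C(Nc1ccc(Cl)cc1CN1C(=O)c2ccccc2C1=O)c1ccco1` gives 2300 nM; of the two numbers recorded it is the higher one, but the nearest value, that of compound 1, is within the scatter a 1.5-fold higher number from compound 1 to compound 3 (0.19 log units; within the scatter). Compound 4 `O=C(Nc1ccc(Cl)cc1CN1C(=O)c2ccccc2C1=O)c1ncccn1` carries pyrimidin-2-yl in place of furan-2-yl on a carbonyl carbon. For the measured compounds named here, two measured steps bear on this: an at least 43-fold lower number from compound 2 to compound 3 (1.63 log units; beyond the scatter) and a 1.5-fold higher number from compound 1 to compound 3 (0.19 log units; within the scatter), so the arene on the carbonyl can swing the result from a limit to a number, and the direction for a pyrimidin-2-yl is open. Compound 4 is expected to stay near compound 3, with a wide range, a 1.5-fold higher number from compound 3 to compound 4 (0.18 log units; within the scatter), giving an estimated 3500 nM between 800 nM and 40000 nM.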

Compound 4, half-maximal effective concentration: 2100 nM
Estimate against measurement, compound 4: 1.7-fold (0.22 log units) above; measured number inside the range.
By their numbers in this assay, from the lowest: compounds 1, 4 and 3 (each within the scatter of the next). At a limit, above all of these: compound 2.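

Pyrimidin-2-yl on the carbonyl carbon gives a result level with furan-2-yl (a 1.1-fold lower number from compound 3 to compound 4 (0.04 log units; within the scatter)) and with the 3-methoxyphenyl of compound 1 (a 1.4-fold higher number from compound 1 to compound 4 (0.15 log units; within the scatter)), so a measurable number in this series does not depend on a furan oxygen or a methoxy. Against the plain phenyl the change is large (an at least 47-fold lower number from compound 2 to compound 4 (1.67 log units; beyond the scatter)), and ring nitrogens now join the replacements that restore a number. Compound 2 sits at a limit, not a number: the limit of > 100000 nM in this assay, at which 1 of the 4 values shown sits.

On these data alone, whether pyridin-2-yl, with a single ring nitrogen, is enough remains open in this assay. So does the effect of an amine or a carboxylic acid on the pyrimidin-2-yl ring.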